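Methoxy to Hydroxy on a Cytotoxicity-Silent Scaffold

The compounds below may be only part of what the source reports. "The series", "measured", "known", "first", "only" and "open" are said of these compounds alone.

Compound 2 `COc1ccc(NC(=O)CSC(=S)N[C@H]2CCOC2=O)cc1` and compound 1 `Cc1cccc(NC(=O)CSC(=S)N[C@H]2CCOC2=O)c1` share a core that differs only in the substituent on the aromatic ring. In a functional assay on SMMC-7721 cells (Homo sapiens) for cytotoxicity, read by MTT assay, with a stated time of 72 h (on this read-out lower numbers stand for stronger inhibition and higher numbers for weaker inhibition), compound 2 gives only a limit, > 128000 nM. In this assay compound 1 likewise gives only a limit, > 128000 nM. Both readings sit at the edge of what the assay reports (the limit of > 128000 nM in this assay, at which 2 of the 2 values shown sit). Compound 3 `O=C(CSC(=S)N[C@H]1CCOC1=O)Nc1ccc(O)cc1` differs from compound 2 by hydrogen in place of methyl on an oxygen on an aromatic ring. Within the data shown here, no measured step exists, so no change beyond the scatter is expected from compound 2 to compound 3. The expected step is a step that the limit leaves unreadable from compound 2 to compound 3. Compound 3 is estimated at 150000 nM, within 40000 nM to 500000 nM.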

Compound 3, half-maximal inhibitory concentration: > 128000 nM
Compound 3 ended at the assay's limit; the forecaster's own chance of this, stated with the estimate: 80%; the middle value is on the limit's open side.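

No step can be read between compound 1, compound 2 and compound 3, since each gives only a limit: the limit of > 128000 nM in this assay, at which 3 of the 3 values shown sit. The compounds shown leave open whether methoxy to hydroxy changes anything in this assay.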